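The source may report more compounds than this note shows. Statements on the series, on what has been measured and on what is new or still open speak of the compounds shown alone.

Measured so far:
compound 1 `OCC(O)Cn1nc2c(Br)c(Br)c(Br)c(Br)c2n1` — 60%
compound 2 `OC(CCn1nc2c(Br)c(Br)c(Br)c(Br)c2n1)c1ccc(Br)cc1` — 89%
compound 3 `OC(CCn1nc2c(Br)c(Br)c(Br)c(Br)c2n1)c1ccccc1` — 89%

In a functional assay on CCRF-CEM cells (Homo sapiens) for antiproliferative activity, read by MTT assay, with a stated time of 48 h, tested at 12.5 uM (on this read-out lower numbers stand for a stronger effect and higher numbers for a weaker effect at the one concentration tested), compound 1 gives the lowest of the three numbers, standing beyond the scatter apart from both compound 2 and compound 3. Among the compounds with values here, the only measured step, no change at the digits printed from compound 2 to compound 3 (within the scatter), concerns a bromo on an aromatic carbon and does not touch the chain that changes here. Compound 4 `C[C@@H](O)CCn1nc2c(Br)c(Br)c(Br)c(Br)c2n1` differs from compound 1 as follows: 2-hydroxypropyl in place of 1,2-dihydroxyethyl on a saturated chain carbon bound to an aromatic nitrogen. Within the data shown here, no measured pair tests this change, so it is judged only against compounds 2 and 3, whose longer hydroxyalkyl chains carrying an aryl group give weaker numbers. Compound 4 is therefore expected to show a modest step of a number 12 percentage points higher from compound 1 to compound 4 (beyond the scatter) towards a weaker effect, estimated at 72% with a range of 50% to 95%.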

Compound 4, a percentage reported as activity, at one concentration (the size of the read-out at that concentration, not a potency): 94%
Beside the measured number, compound 4's estimate is 22 percentage points below it; measured number inside the range.
By their numbers in this assay, from the lowest: compound 1; then compounds 2, 3 and 4 (each within the scatter of the next).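

In this assay, the chain on a saturated chain carbon bound to an aromatic nitrogen proves decisive, as 2-hydroxypropyl in place of 1,2-dihydroxyethyl gives a number 34 percentage points higher from compound 1 to compound 4 (beyond the scatter) on an otherwise shared core. The entering group has no ring, so a large step at this position arises without any aryl group. No available evidence explains the step. Since the two groups differ in both their carbon and oxygen counts, the data do not separate those two changes. On these data alone, whether an amine or a carboxylic acid on this chain would retain the effect of compound 1 remains open.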